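The compounds below may be only part of what the source reports. "The series", "measured", "known", "first", "only" and "open" are said of these compounds alone.

In a functional assay on HaCaT cells (Homo sapiens) for cytotoxicity, read by MTT assay, with a stated time of 48 h (on this read-out lower numbers stand for stronger inhibition and higher numbers for weaker inhibition), compound 3 `CCC(CC)(c1ccc(OCC(O)C(C)(C)C)c(C)c1)c1ccc(C(=O)N[C@H](CO)CCO)n1C` gives the lowest number at 190 nM, against compound 2 `CCC(CC)(c1ccc(OCC(O)C(C)(C)C)c(C)c1)c1ccc(C(=O)N[C@@H](C)CO)n1C` at 15700 nM and compound 1 `CCC(CC)(c1ccc(OCC(=O)C(C)(C)C)c(C)c1)c1ccc(C(=O)NCCC(=O)OC)n1C` at 28900 nM. Compound 4 `CCn1c(C(=O)N[C@H](CO)CCO)ccc1C(CC)(CC)c1ccc(OCC(O)C(C)(C)C)c(C)c1` differs from compound 3 by methyl in place of hydrogen on a saturated chain carbon bound to an aromatic nitrogen, or methyl to ethyl. For the measured compounds named here, the only measured step, an 83-fold lower number from compound 2 to compound 3 (1.92 log units; beyond the scatter), is large but involves hydroxymethyl at another place, so it bears only indirectly and no measured step covers this change. Only a modest shift towards the higher numbers of the series is expected in this assay. The expected step is a 1.6-fold higher number from compound 3 to compound 4 (0.20 log units; within the scatter). For compound 4 the estimate is 300 nM, with an expected range from 70 nM to 2500 nM.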

Compound 4, half-maximal inhibitory concentration: 1250 nM
Compound 4: middle estimate off by 4.2-fold (0.62 log units), on the low side; low and high end bracket the measured number.
By their numbers in this assay, from the lowest: compound 3; then compound 4; then compounds 2 and 1 (each within the scatter of the next).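

In this assay, methyl in place of hydrogen on a saturated chain carbon bound to an aromatic nitrogen gives a 6.6-fold higher number from compound 3 to compound 4 (0.82 log units; beyond the scatter), a modest step beyond the scatter. For the compounds shown here, none of the earlier steps touched this position, and this one shows that the number responds to a single added carbon here, in the direction of weaker inhibition. No measurement on hand explains the step.

On these data alone, whether a longer chain such as propyl at this place would raise the number further remains open. So does whether methyl to ethyl has the same effect with the amide side chain of compound 2.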